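The source may hold more compounds than are shown below. What is called first, only, known or untested is meant among the compounds shown, and "the series" means these compounds.

Measured compounds in a functional assay on HT-1080 cells (Homo sapiens) for cytotoxicity, read by MTT assay, with a stated time of 72 h; a higher number here means a weaker inhibitor, a lower number a stronger inhibitor:
- compound 1 `COc1ccc(Cn2nc(-c3ccccc3)c3cc(C(=N)Nc4ccc(N5CCN(C)CC5)cc4)nc(Nc4cc(OC)c(OC)c(OC)c4)c32)cc1` gives 1200 nM
- compound 2 `N=C(Nc1ccccc1)c1cc2c(-c3ccccc3)n[nH]c2cn1` gives 22000 nM
- compound 3 `COc1ccc(Cn2nc(-c3ccccc3)c3cc(C(=N)Nc4ccccc4)nc(Nc4cc(OC)c(OC)c(OC)c4)c32)cc1` gives 11100 nM

Compound 2 carries the highest number of the three; its value and that of compound 3 lie within the scatter of each other, while the gap to compound 1 is beyond it. The difference between the core of compound 2 and the core of compound 3 is not broken down here.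

Within the larger core, the one counted change is 4-methylpiperazin-1-yl in place of hydrogen on an aromatic carbon; it made the step of a 9.3-fold lower number from compound 3 to compound 1 (0.97 log units; beyond the scatter).

Compound 4 `CN1CCN(c2ccc(NC(=N)c3cc4c(-c5ccccc5)n[nH]c4cn3)cc2)CC1` is unmeasured. It differs from compound 2 by 4-methylpiperazin-1-yl in place of hydrogen on an aromatic carbon, the same change as that from compound 3 to compound 1, at the same kind of place. The expectation for compound 4 in this assay rests on a single precedent, seen on a different core, so the step is taken as likely somewhat smaller than the measured one: the estimated step is a 6.3-fold lower number from compound 2 to compound 4 (0.80 log units; beyond the scatter). Compound 4 is thus expected to give about 3500 nM, with a range from 1200 nM to 11000 nM.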

Compound 4, half-maximal inhibitory concentration: 11400 nM
For compound 4 the middle estimate is 3.3-fold (0.51 log units) below the measured one; measured number outside the range, above it.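

In this assay, 4-methylpiperazin-1-yl in place of hydrogen on an aromatic carbon gives a 1.9-fold lower number from compound 2 to compound 4 (0.29 log units; within the scatter), a step that stays within the scatter on the core of compound 2. The change therefore does not carry over at one size from the larger core to the smaller one: the same change on two cores in this assay, a 9.3-fold lower number (0.97 log units; beyond the scatter) from compound 3 to compound 1 and a 1.9-fold lower number (0.29 log units; within the scatter) from compound 2 to compound 4, 4.8-fold (0.68 log units) apart, beyond the scatter of two such steps

Among these compounds, with only two pairs, this shows that the size of the step depends on the core, but it does not show why, nor does it predict the step on any further core.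

Open, from the compounds shown here alone, is whether a morpholine or an unsubstituted piperazine at the same place would give a step like either of the two seen with 4-methylpiperazin-1-yl. Among the compounds shown here, also open is which of the groups present on the core of compound 1 but absent from the core of compound 2 goes with the larger step, a question that needs compounds carrying only one of those groups.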